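Replacing 2-fluorophenyl with furan-2-yl on the shared core

A few compounds are considered here, and "the series" means these few. Any claim that something is new, unique, unknown or untested is made for them only; others in the source may bear on it.

In a functional assay on MCF7 cells (Homo sapiens) for antiproliferative activity, read by MTT assay, with a stated time of 72 h (on this read-out lower numbers stand for stronger inhibition and higher numbers for weaker inhibition), compound 3 `CC1=CC[C@H]2[C@H](CC[C@]2(C)O)C(C)(C)[C@@H]1CC[C@H]1[C@]2(C)CC[C@H](OC(=O)c3ccccc3F)C(C)(C)O[C@H]2CC[C@@]1(C)O` gives 11300 nM and compound 2 `CC1=CC[C@H]2[C@H](CC[C@]2(C)O)C(C)(C)[C@@H]1CC[C@H]1[C@]2(C)CC[C@H](OC(=O)c3ccc(Cl)c(Cl)c3)C(C)(C)O[C@H]2CC[C@@]1(C)O` gives 11900 nM, with a 1.1-fold lower number from compound 2 to compound 3 (0.02 log units; within the scatter). Compound 1 `CC1=CC[C@H]2[C@H](CC[C@]2(C)O)C(C)(C)[C@@H]1CC[C@H]1[C@]2(C)CC[C@H](OC(=O)c3ccncc3)C(C)(C)O[C@H]2CC[C@@]1(C)O` gives 25300 nM, the highest number of the three. Compound 4 `CC1=CC[C@H]2[C@H](CC[C@]2(C)O)C(C)(C)[C@@H]1CC[C@H]1[C@]2(C)CC[C@H](OC(=O)c3ccco3)C(C)(C)O[C@H]2CC[C@@]1(C)O` carries furan-2-yl in place of 2-fluorophenyl on a carbonyl carbon. Among the compounds with values here, no measured step makes this exact change. The closest guides are a 2.2-fold lower number from compound 1 to compound 3 (0.35 log units; beyond the scatter) and a 2.1-fold lower number from compound 1 to compound 2 (0.33 log units; beyond the scatter), both leading away from pyridin-4-yl, which like furan-2-yl has a hetero atom in its ring. A small rise is therefore expected, with an estimated step of a 1.4-fold higher number from compound 3 to compound 4 (0.15 log units; within the scatter). For compound 4 the estimated value is 16000 nM, with an expected range of 9000 nM to 28000 nM.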

Compound 4, half-maximal inhibitory concentration: 25700 nM
The estimate for compound 4 lay 1.6-fold (0.21 log units) below the measured number; the range from low to high includes it.
By their numbers in this assay, from the lowest: compounds 3 and 2 (each within the scatter of the next); then compounds 1 and 4 (each within the scatter of the next).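

In this assay, moving from a ring of carbon only to furan-2-yl on this carbonyl carbon gives a modest rise whichever such ring leaves (a 2.3-fold higher number from compound 3 to compound 4 (0.36 log units; beyond the scatter); a 2.2-fold higher number from compound 2 to compound 4 (0.33 log units; beyond the scatter)). Furan-2-yl and pyridin-4-yl, the two rings with a hetero atom, cannot be told apart (a 1.0-fold higher number from compound 1 to compound 4 (0.01 log units; within the scatter)), so among these four compounds the numbers fall into two pairs by ring type, with no compound going against this. Nothing available here explains this split. The compounds shown leave open whether a phenyl ring carrying an amine, or a plain alkyl chain in place of the ring, would fall with either pair.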